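Triazolylmethyl Spirooxindoles Against Colon Carcinoma Cell Growth

The source may report more compounds than this note shows. Statements on the series, on what has been measured and on what is new or still open speak of the compounds shown alone.

Compound 1 `Cc1cccc(-n2nncc2CN2C(=O)C3(C(C#N)=C(N)Oc4c3c3nc5ccccc5nc3c3ccccc43)c3ccccc32)c1` in a functional assay on HCT-116 cells (Homo sapiens) for antiproliferative activity, read by MTT assay, with a stated time of 48 h; on this read-out higher numbers stand for weaker inhibition and lower numbers for stronger inhibition: > 50000 nM (a limit)
Compound 2 `Cc1ccc(Cl)cc1-n1nncc1CN1C(=O)C2(C(C#N)=C(N)Oc3c2c2nc4ccccc4nc2c2ccccc32)c2ccccc21` in this assay: > 50000 nM (a limit)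
Compound 3 `N#CC1=C(N)Oc2c(N)cc3nc4ccccc4nc3c2C12C(=O)N(Cc1cnnn1-c1cccc(C(F)(F)F)c1)c1ccccc12` in this assay: 18900 nM

Compound 1 gives > 50000 nM, which is a limit of the assay and not a number. Compound 2 likewise gives > 50000 nM, also a limit. Among the measured compounds shown here, compound 3 gives 18900 nM, the one actual number in this set; the limit of > 50000 nM in this assay, at which 2 of the 3 values shown sit, holds the other two values. The step that the two limits leave unreadable from compound 1 to compound 2 is therefore unreadable and offers no guide. Compound 4 `CCc1cccc(CC)c1-n1nncc1CN1C(=O)C2(C(C#N)=C(N)Oc3c(N)cc4nc5ccccc5nc4c32)c2ccccc21` differs from compound 3 by 2,6-diethylphenyl in place of 3-(trifluoromethyl)phenyl on an aromatic nitrogen. For the measured compounds named here, no measured step bears on this change, so no shift beyond the scatter is expected; the step of a 1.3-fold higher number from compound 3 to compound 4 (0.12 log units; within the scatter) is an estimate resting on compound 3 alone. Compound 4 is expected at 25000 nM, within 8000 nM to 60000 nM.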

Compound 4, half-maximal inhibitory concentration: 37600 nM
Beside the measured number, compound 4's estimate is 1.5-fold (0.18 log units) below it, within the range that was stated.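

Across this assay, the step of a 2.0-fold higher number from compound 3 to compound 4 (0.30 log units; within the scatter) is the first readable change at this aromatic nitrogen. It shows that 2,6-diethylphenyl and 3-(trifluoromethyl)phenyl, each of 10 heavy atoms, give values that cannot be separated here, whereas the earlier step cannot be read because compound 1 and compound 2 both sit at a limit. Nothing measured here gives a cause for this result. Going by these compounds, whether an amine or a carboxylic acid on this phenyl ring would shift the value beyond the scatter remains open.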